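The compounds below may be only part of what the source reports. "The series", "measured", "known", "first", "only" and "open" are said of these compounds alone.

Compound 1 `Cc1cccc(CSc2cc(Cl)c(C)cc2S(=O)(=O)/N=C(\N)n2nccc2-c2ccccc2)c1` gives 8000 nM in a functional assay on HeLa cells (Homo sapiens) for cytotoxicity, read by MTT assay, with a stated time of 72 h; a higher number here means a weaker inhibitor, a lower number a stronger inhibitor.
Compound 2 `Cc1cc(S(=O)(=O)/N=C(\N)n2nccc2-c2ccccc2)c(SCc2ccccc2C)cc1Cl` gives 17000 nM.
Compound 3 `Cc1cc(-c2ccccc2)n(/C(N)=N/S(=O)(=O)c2cc(C)c(Cl)cc2SCc2ccc(Cl)cc2)n1` gives 3000 nM.

Among these three numbers compound 1 stands second highest: compound 2 sits above it and compound 3 below it, both beyond the scatter. Compound 4 `Cc1cc(S(=O)(=O)/N=C(\N)n2nccc2-c2ccccc2)c(SCc2ccccc2Cl)cc1Cl` differs from compound 1 in one place: 2-chlorophenyl in place of 3-methylphenyl on a saturated chain carbon bound to a sulfur. Going by the values given here, one measured step bears on this change. Moving the ring substituent in the same place gave a 2.1-fold higher number from compound 1 to compound 2 (0.33 log units; beyond the scatter), a modest rise. Among the compounds with values here, compound 3 gives a lower number than compound 1, yet no single step connects those two, so it offers no clean guide. The change to compound 4 combines a shift of the substituent with a swap of methyl for chlorine, and only the first part has a measured counterpart. A modest rise in this assay, or none beyond the scatter, is therefore expected. The estimate for compound 4 is 10000 nM (range 4000 nM to 25000 nM), which is expected to mean a 1.3-fold higher number from compound 1 to compound 4 (0.10 log units; within the scatter).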

Compound 4, half-maximal inhibitory concentration: 19000 nM
The estimate for compound 4 lay 1.9-fold (0.28 log units) below the measured number; low and high end bracket the measured number.
By their numbers in this assay, from the lowest: compound 3; then compound 1; then compounds 2 and 4 (each within the scatter of the next).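

In this assay, 2-chlorophenyl in place of 3-methylphenyl on a saturated chain carbon bound to a sulfur gave a 2.4-fold higher number from compound 1 to compound 4 (0.38 log units; beyond the scatter), a modest rise that shows this change is not neutral. Chloro in place of methyl on an aromatic carbon gave a 1.1-fold higher number from compound 2 to compound 4 (0.05 log units; within the scatter), so 2-chlorophenyl and 2-methylphenyl cannot be told apart here, and in these compounds the methyl-to-chloro swap adds nothing that can be read beyond the step from 3-methylphenyl to 2-methylphenyl. No measurement here accounts for these differences.

From the compounds shown here alone, whether a 3-chlorophenyl, an unsubstituted phenyl or a 2-methoxyphenyl at this place would fall with compound 1 or with compound 2 and compound 4 remains open. Going by these compounds alone, also open is whether the same order would hold with the other groups of the core changed, as compound 3 is joined to these compounds by no single step.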